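The compounds below may be only part of what the source reports. "The series", "measured", "known", "first", "only" and "open" are said of these compounds alone.

In an ADME assay on the whole organism (Mus musculus, strain C57) for pharmacokinetics (on this read-out higher numbers stand for wider distribution into tissues and lower numbers for narrower distribution), compound 1 (`Cc1cc(C(F)(F)F)ccc1-c1cc2cnn([C@@H](CC(C)C)c3ccc(C(=O)NCCC(=O)O)cc3)c2cc1C`) gives 0.87 L/kg. Going by the values given here, the only other measured compound, compound 2 (`Cc1cc(C(F)(F)F)ccc1-c1cc2cn([C@@H](CC(C)C)c3ccc(C(=O)NCCC(=O)O)cc3)nc2cc1C`), gives 1.56 L/kg. These two numbers lie within the usual scatter of each other, so compound 1 does not stand apart from compound 2. Compound 3 (`Cc1cc2c(cnn2[C@@H](CC(C)C)c2ccc(C(=O)NCCC(=O)O)cc2)cc1-c1ccc(C(F)(F)F)cc1Cl`) keeps the core of compound 1 and alters one substituent: chloro in place of methyl on an aromatic carbon. In words, chloro takes the place of methyl on an aromatic carbon, turning 2-methyl-4-(trifluoromethyl)phenyl into 2-chloro-4-(trifluoromethyl)phenyl. Among the compounds with values here, no measured pair of compounds shows this swap, so the data give no direct guide to its effect. A step beyond the scatter is not expected, and neither direction is favoured. The expected step is small: a 1.0-fold higher number from compound 1 to compound 3 (0.01 log units; within the scatter). For compound 3 the estimated value is 0.9 L/kg, with an expected range from 0.5 L/kg to 1.6 L/kg.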

Compound 3, volume of distribution at steady state: 1.45 L/kg
Compound 3: middle estimate off by 1.6-fold (0.21 log units), on the low side; the range from low to high includes it.
By their numbers in this assay, from the lowest: compounds 1, 3 and 2 (each within the scatter of the next).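

Placing chloro instead of methyl on this aromatic carbon, ortho to a large group and meta to a trifluoromethyl group, gives a 1.7-fold higher number from compound 1 to compound 3 (0.22 log units; within the scatter) in this assay. Going by these compounds alone, this is the first measured pair for this swap, and it shows that this single change at this position does not move tissue distribution beyond the usual scatter. Nothing available gives a reason for the size of this step.

The compounds shown leave open whether a fluoro, a methoxy or a nitrile at the same position would also stay within the scatter of compound 1. On these data alone, it also remains open whether chloro in place of methyl would give a similar step on the core of compound 2.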